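Hydroxy and amino groups on the sulfur chain

The source may hold more compounds than are shown below. What is called first, only, known or untested is meant among the compounds shown, and "the series" means these compounds.

In a functional assay on HT cells (Homo sapiens) for antiproliferative activity, read by fluorescence, with a stated time of 72 h (on this read-out lower numbers stand for stronger inhibition of growth and higher numbers for weaker inhibition of growth), compound 1 (`CC(C)c1n[nH]c2c(NCc3ccc(-c4ccccn4)cc3)nc(SCCO)nc12`) reads 48 nM and compound 2 (`CC(C)c1n[nH]c2c(NCc3ccc(-c4ccccn4)cc3)nc(SC(C)C(C)O)nc12`) reads 190 nM and compound 3 (`CC(C)c1n[nH]c2c(NCc3ccc(-c4ccccn4)cc3)nc(SCCCN(C)C)nc12`) reads 105 nM in this set. Two steps fix its place: a 1.8-fold lower number from compound 2 to compound 3 (0.26 log units; within the scatter) and a 2.2-fold higher number from compound 1 to compound 3 (0.34 log units; beyond the scatter).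

Compound 4 (`CC(C)c1n[nH]c2c(NCc3ccc(-c4ccccn4)cc3)nc(SC[C@H](O)CN)nc12`) has 3-amino-2-hydroxypropyl in place of 3-(dimethylamino)propyl on the sulfur, counted as 2-amino-1-hydroxyethyl in place of 2-(dimethylamino)ethyl on a saturated chain carbon bound to a sulfur. The steps bearing on this are a 2.2-fold higher number from compound 1 to compound 3 (0.34 log units; beyond the scatter) and a 4.0-fold higher number from compound 1 to compound 2 (0.60 log units; beyond the scatter), both modest. Neither covers a chain holding both hydroxy and amino groups, so only a small change is expected. No step beyond the scatter is expected in this assay, the estimated change being a 1.2-fold lower number from compound 3 to compound 4 (0.09 log units; within the scatter). For compound 4 the estimated value is 85 nM, with an expected range of 35 nM to 210 nM.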

Compound 4, concentration for 50% growth inhibition: 63 nM
Estimate against measurement, compound 4: 1.3-fold (0.13 log units) above; low and high end bracket the measured number.
By their numbers in this assay, from the lowest: compounds 1, 4, 3 and 2 (each within the scatter of the next, the first and the last beyond it).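

In this assay, the 3-amino-2-hydroxypropyl chain shows that hydroxy and amino groups can stand on one sulfur chain with no step beyond the scatter against the 2-hydroxyethyl chain (a 1.3-fold higher number from compound 1 to compound 4 (0.12 log units; within the scatter)) or the 3-(dimethylamino)propyl chain (a 1.7-fold lower number from compound 3 to compound 4 (0.22 log units; within the scatter)). Among these compounds, only the step against the 2-hydroxy-1-methylpropyl chain lies beyond the scatter (a 3.0-fold lower number from compound 2 to compound 4 (0.48 log units; beyond the scatter)). No evidence on the cause of these steps is available. Still open, going by these compounds, is how a dimethylamino group, a carboxylic acid or a longer chain would read in place of the primary amine on this hydroxy chain.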